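Working notes: microsomal half-life from compound 1 to compound 4

The source may hold more compounds than are shown below. What is called first, only, known or untested is meant among the compounds shown, and "the series" means these compounds.

Compound 1 `Cc1cc(-c2ccccc2)n(/C(N)=N/S(=O)(=O)c2cc(C)c(Cl)cc2SCc2ccccc2C)n1` gives 0.154 h in an ADME assay on microsomes from liver (Homo sapiens) for metabolic stability, read by LC-MS, using NADPH, tested at 5 uM (on this read-out lower numbers stand for a shorter-lived compound and higher numbers for a longer-lived compound), and shows the lowest of the three numbers measured, with compound 2 `Cc1cccc(CSc2cc(Cl)c(C)cc2S(=O)(=O)/N=C(\N)n2nccc2-c2ccccc2)c1` at 0.232 h and compound 3 `Cc1cc(S(=O)(=O)/N=C(\N)n2nccc2-c2ccccc2)c(SCc2cccc(Cl)c2)cc1Cl` at 0.309 h both within the scatter of it. For the measured compounds named here, the only single-point step among measured compounds, a 1.3-fold higher number from compound 2 to compound 3 (0.12 log units; within the scatter), also exchanges one substituent on the benzyl ring and stays within the scatter. Compound 4 `Cc1cc(-c2ccccc2)n(/C(N)=N/S(=O)(=O)c2cc(C)c(Cl)cc2SCc2cccc(C(F)(F)F)c2)n1` differs from compound 1 as follows: 3-(trifluoromethyl)phenyl in place of 2-methylphenyl on a saturated chain carbon bound to a sulfur. Going by the values given here, no measured step covers a trifluoromethyl group, so the expectation rests on the small benzyl-ring step seen. Compound 4 is therefore expected to give 0.17 h, within a range of 0.08 h to 0.35 h. The expected step is a 1.1-fold higher number from compound 1 to compound 4 (0.04 log units; within the scatter), none beyond the scatter.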

Compound 4, half-life: 0.169 h
Beside the measured number, compound 4's estimate is 1.0-fold (0.00 log units) above it; low and high end bracket the measured number.
By their numbers in this assay, from the lowest: compounds 1, 4, 2 and 3 (each within the scatter of the next).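

In this assay, 3-(trifluoromethyl)phenyl in place of 2-methylphenyl on a saturated chain carbon bound to a sulfur gives a 1.1-fold higher number from compound 1 to compound 4 (0.04 log units; within the scatter). This position therefore accepts the larger, fluorine-bearing group with no half-life difference that can be told from the scatter. No measurement at hand bears on why this exchange leaves the read-out unresolved. Open, from the compounds shown here alone, is whether an amine, a carboxylic acid or a longer chain at this position would give a step beyond the scatter.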